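The compounds below may be only part of what the source reports. "The series", "measured", "known", "first", "only" and "open" are said of these compounds alone.

Three compounds share one core and were tested in a functional assay on K562 cells (Homo sapiens) for cytotoxicity; a lower number here means a stronger inhibitor, a higher number a weaker inhibitor. Compound 1 `CCN(CC)C(=S)SCc1ccc2nc(C)nc(O)c2c1` gives 4400 nM. Compound 3 `Cc1nc(O)c2cc(CSC(=S)N(C3CCCCC3)C3CCCCC3)ccc2n1` gives 7600 nM. Compound 2 `Cc1nc(O)c2cc(CS/C(S)=N/C3CCCCC3)ccc2n1` gives 31000 nM, the highest of the three numbers, and its gaps to compound 3 and to compound 1 both lie beyond the usual scatter. Compound 4 `Cc1nc(O)c2cc(CS/C(S)=N/Cc3ccco3)ccc2n1` differs from compound 2 by (furan-2-yl)methyl in place of cyclohexyl on a double-bonded nitrogen. For the measured compounds named here, no measured pair shows this change, so its effect is unknown. Compound 4 keeps a single group on that nitrogen, as compound 2 does, so its number is expected to stay near the value of compound 2, 31000 nM. The expected step is a 1.6-fold lower number from compound 2 to compound 4 (0.19 log units; within the scatter), a modest move toward a lower number. The estimate for compound 4 is 20000 nM, with a range from 6000 nM to 70000 nM.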

Compound 4, half-maximal inhibitory concentration: 2100 nM
The estimate for compound 4 lay 9.5-fold (0.98 log units) above the measured number; the measured number lies below the stated range.
By their numbers in this assay, from the lowest: compound 4; then compounds 1 and 3 (each within the scatter of the next); then compound 2.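

In this assay, the change on the double-bonded nitrogen gives a 15-fold lower number from compound 2 to compound 4 (1.17 log units; beyond the scatter), so the group at this position can strongly shift the number, even between two groups of equal heavy-atom count. The entering group brings a five-membered aromatic ring and a hydrogen-bond acceptor, but no measurement here explains the shift. The compounds shown leave open which part of the (furan-2-yl)methyl group goes with the lower number: its ring, its oxygen or its methylene carbon. A benzyl or cyclohexylmethyl group on that nitrogen could help separate these.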